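A Second Fluoro on Compound 2

The compounds below may be only part of what the source reports. "The series", "measured", "known", "first", "only" and "open" are said of these compounds alone.

Compound 1 `Cc1cc(Nc2nc(NCc3cccc(Cl)c3)nc3[nH]ncc23)n[nH]1` gives 5620 nM
Compound 2 `Cc1cc(Nc2nc(NCc3ccc(F)cc3)nc3[nH]ncc23)n[nH]1` gives 970 nM

Both values come from a functional assay on MCF7 cells (Homo sapiens) for inhibition, read by MTT assay, with a stated time of 5 days (a lower number here means a stronger inhibitor, a higher number a weaker inhibitor), and compound 2, at 970 nM in this series, holds the lower of the two numbers. The next compound is compound 3 `Cc1cc(Nc2nc(NCc3ccc(F)cc3F)nc3[nH]ncc23)n[nH]1` and it departs from compound 2 in one place. That change, fluoro in place of hydrogen on an aromatic carbon in full, is fluoro in place of hydrogen on an aromatic carbon, which turns 4-fluorophenyl into 2,4-difluorophenyl.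

Among the compounds with values here, one measured step bears on it. The value moved by a 5.8-fold lower number from compound 1 to compound 2 (0.76 log units; beyond the scatter) when 4-fluorophenyl took the place of 3-chlorophenyl. That step touches the same phenyl group and is modest, but it exchanges one substituent for another at different places. Within the data shown here, no measured pair shows a fluoro added to a phenyl group that already carries one, so the data give no direction for this change. A step smaller than that one is expected, quite possibly within the scatter. The estimated move is a 1.1-fold lower number from compound 2 to compound 3 (0.03 log units; within the scatter) in this assay terms. Compound 3 is expected at 900 nM by this estimate, with an estimated range from 350 nM to 2800 nM around it.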

Compound 3, half-maximal inhibitory concentration: 670 nM
Beside the measured number, compound 3's estimate is 1.3-fold (0.13 log units) above it; the range from low to high includes it.
By their numbers in this assay, from the lowest: compounds 3 and 2 (each within the scatter of the next); then compound 1.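

In this assay, adding a fluoro ortho to a large group and meta to the existing fluoro group gives a 1.4-fold lower number from compound 2 to compound 3 (0.16 log units; within the scatter), so on this one pair the 2,4-difluorophenyl and 4-fluorophenyl compounds cannot be told apart, and this carbon accepts the second fluoro without a step that stands clear of the scatter. The comparison with the 3-chlorophenyl compound gives an 8.4-fold lower number from compound 1 to compound 3 (0.92 log units; beyond the scatter) and stays beyond the scatter, so the separation from compound 1 already seen with compound 2 persists with the second fluoro in place. No supporting measurement is available to explain either step, and none bears on this result.

The compounds shown leave open whether a larger group at this same carbon, such as chloro, methoxy or trifluoromethyl, would also leave the value within the scatter of compound 2, or whether this single fluoro addition is a special case. They also leave open how a 2-fluorophenyl group without the 4-fluoro would read, and whether a longer chain to the 2,4-difluorophenyl group would keep the values seen here.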